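Nitro to Amino: One Change on Compound 2

This account rests on a few compounds, and the source may have more. Where it says the series, first, only, none or still open, it means among the compounds named here.

Measured so far:
- Compound 1, `Nc1ccccc1S(=O)(=O)N1CC(n2cc(F)c(=O)[nH]c2=O)OCc2ccccc21`: in a functional assay on MCF7 cells (Homo sapiens) for antiproliferative activity (a higher number here means a weaker inhibitor, a lower number a stronger inhibitor), compound 1 gives 54800 nM
- Compound 2, `O=[N+]([O-])c1ccccc1S(=O)(=O)N1CC(n2cnc3ncnc(Cl)c32)OCc2ccccc21`: in this assay compound 2 gives 920 nM

Compound 2 stands at the lowest of the two numbers; its nearest neighbour, compound 1, sits at a markedly higher number, a gap well beyond the usual scatter. Compound 1 and compound 2 differ in two places at once, so the two values cannot be split into the share of each change.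

Compound 3, `Nc1ccccc1S(=O)(=O)N1CC(n2cnc3ncnc(Cl)c32)OCc2ccccc21`, keeps the core and the second ring system of compound 2 and changes only the group on the phenyl ring: amino in place of nitro on an aromatic carbon.

Going by the values given here, no measured pair shows this change on its own, so there is no direct step to lean on. A change of this size on the sulfonamide-bearing ring may leave the number roughly where it is or move it modestly; without a reference step, the expectation is for a step from compound 2 to compound 3 of a 1.6-fold higher number from compound 2 to compound 3 (0.21 log units; within the scatter) in this assay, which could fall within the scatter. Compound 3 is therefore estimated at 1500 nM, in the range 300 nM to 8000 nM.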

Compound 3, half-maximal inhibitory concentration: 9140 nM
Estimate against measurement, compound 3: 6.1-fold (0.78 log units) below; the measured number lies above the stated range.
By their numbers in this assay, from the lowest: compound 2; then compound 3; then compound 1.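

In this assay, the exchange of nitro for amino on the phenyl ring gives a 9.9-fold higher number from compound 2 to compound 3 (1.00 log units; beyond the scatter) with the core and the second ring system held fixed, so the group at this place on the sulfonamide-bearing ring clearly affects the number. With the amino group held fixed instead, exchanging the ring system on the saturated ring carbon gives a 6.0-fold lower number from compound 1 to compound 3 (0.78 log units; beyond the scatter) and shows that this second place matters as well. Compound 3 thus divides the gap between compound 1 and compound 2, which could not be split before, into two single changes that each lie beyond the scatter, and nothing shown here accounts for the size of either one.

The compounds shown leave open whether nitro in place of amino would bring a similar step on the ring system of compound 1, since the nitro group has so far been seen with only one ring system. They also leave open how other groups at this place on the phenyl ring, such as a carboxylic acid, a methoxy group or a plain hydrogen, would compare with nitro and amino.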